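A few compounds are considered here, and "the series" means these few. Any claim that something is new, unique, unknown or untested is made for them only; others in the source may bear on it.

Compound 1, `CN(C)C/C=C(/c1ccc(Cl)cc1)c1cccnc1`, is the anchor of this comparison. In a functional assay on brain for inhibition of Norepinephrine transporter (Rattus norvegicus) (on this read-out higher numbers stand for weaker inhibition and lower numbers for stronger inhibition), compound 1 gives 10000 nM, the lower of the two plain numbers shown. Compound 2, `CCNC/C=C(/c1ccc(Br)cc1)c1cccnc1`, gives 26000 nM in this assay. Compound 3, `CN(C)C/C=C(/c1ccc(I)cc1)c1cccnc1`, reaches only a limit of the assay, > 22000 nM, so no exact number is known for it. For the measured compounds named here, the one single-point change measured is an at least 2.2-fold higher number from compound 1 to compound 3 (0.34 log units; beyond the scatter). Compound 4, `COc1ccc(/C(=C/CN(C)C)c2cccnc2)cc1`, differs from compound 1 by methoxy in place of chloro on an aromatic carbon. Going by the values given here, no measured step swaps chloro for methoxy, so the halogen swap is the only guide, and it points toward a somewhat higher number. Compound 4 is therefore expected to give about 16000 nM in this assay, within a range from 6000 nM to 45000 nM. That estimate means the step of a 1.6-fold higher number from compound 1 to compound 4 (0.20 log units; within the scatter) is expected to be modest.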

Compound 4, half-maximal inhibitory concentration: > 28000 nM
Compound 4: no number, only a limit (the forecaster's own chance of this, stated with the estimate: 30%); middle value at least 1.7-fold (0.24 log units) from the limit.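

In this assay, methoxy in place of chloro gives an at least 2.8-fold higher number from compound 1 to compound 4 (0.44 log units; beyond the scatter). This shows that a group other than a halogen at this place, para to a large group, also weakens inhibition, as iodo did with an at least 2.2-fold higher number from compound 1 to compound 3 (0.34 log units; beyond the scatter), so chloro remains the better of the three replacements compared on this core. Compound 3 and compound 4 both stand only at limits, so the step between them cannot be read.

Still open, on these data alone, is whether a fluoro, hydroxyl or amine group here would bring the number below that of compound 1.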